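This account rests on a few compounds, and the source may have more. Where it says the series, first, only, none or still open, it means among the compounds named here.

Compound 1 `c1ccc(C2Cc3nccn3C2)cc1` gives 15 mL.min-1.g-1; < 7 mL.min-1.g-1 (2 entries) in an in vitro ADME assay on microsomes from liver (Homo sapiens) for metabolic stability; on this read-out higher numbers stand for fast clearance and lower numbers for slow clearance.
Compound 2 `FC(F)Oc1ccccc1C1Cc2nccn2C1` gives 22 mL.min-1.g-1.
Compound 3 `COc1ccccc1C1CCc2nc[nH]c2C1` gives "not determined" (no result reported), so no result is reported for it.

On the numbers shown, compound 3 stands nowhere: it went into this assay, but no single figure came back, and a further entry likewise gives no figure. Compound 4 `c1ccc(C2CCc3nc[nH]c3C2)cc1` differs from compound 3 in one place: hydrogen in place of methoxy on an aromatic carbon. With no number for compound 3, the size of the step from compound 3 to compound 4 cannot be read from the data, and no direction is claimed for it. What can be said rests on compound 1, which carries the same bare phenyl group on a related core. The repeated entries of compound 1 (the several entries of compound 1 in this assay, 15 mL.min-1.g-1; < 7 mL.min-1.g-1 (2 entries)) sit toward the slow end of this read-out. Compound 4 is therefore expected to clear at a slow-to-moderate rate, estimated at 12 mL.min-1.g-1 with a range from 5 mL.min-1.g-1 to 30 mL.min-1.g-1.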

Compound 4, intrinsic clearance in microsomes: 7 mL.min-1.g-1
Estimate against measurement, compound 4: 1.7-fold (0.23 log units) above, within the range that was stated.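

For the compounds shown here, compound 3 has no single number for clearance in liver microsomes, so no step from it to compound 4 can be read from these results. The compounds shown leave open how methoxy in place of hydrogen on the aromatic ring would change clearance on the core of compound 4.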